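The source may report more compounds than this note shows. Statements on the series, on what has been measured and on what is new or still open speak of the compounds shown alone.

Compound 1 `C=C(Br)C(=O)Nc1ccc(/C=C2\SC(=O)N(Cc3ccc(C)cc3)C2=O)cc1`: 3400 nM
Compound 2 `Nc1ccc(/C=C2\SC(=O)N(Cc3ccc(C(F)(F)F)cc3)C2=O)cc1`: 6000 nM
Compound 3 `C=C(Br)C(=O)Nc1ccc(/C=C2\SC(=O)N(Cc3ccc(C(F)(F)F)cc3)C2=O)cc1`: 12000 nM

In a functional assay on L1210 cells (Mus musculus) for cytotoxicity, read by cell counting, with a stated time of 2 days (on this read-out higher numbers stand for weaker inhibition and lower numbers for stronger inhibition), compound 2 gives 6000 nM, the second highest of the three numbers; it sits within the scatter of compound 1, which gives 3400 nM, and of compound 3, which gives 12000 nM. Compound 4 `Nc1ccc(/C=C2\SC(=O)N(Cc3ccccc3)C2=O)cc1` differs from compound 2 in one place: hydrogen in place of trifluoromethyl on an aromatic carbon. Among the compounds with values here, only one measured step speaks to this: a 3.5-fold higher number from compound 1 to compound 3 (0.55 log units; beyond the scatter), a modest rise when trifluoromethyl replaced methyl. Removing the trifluoromethyl altogether is therefore expected to move the number in the other direction, by a similarly modest amount, and the step from compound 2 to compound 4 is estimated as a 2.0-fold lower number from compound 2 to compound 4 (0.30 log units; within the scatter). Compound 4 is thus expected to give about 3000 nM, with a range from 1200 nM to 8000 nM.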

Compound 4, half-maximal inhibitory concentration: 38000 nM
Compound 4: middle estimate off by 13-fold (1.10 log units), on the low side; measured number above the stated range.
By their numbers in this assay, from the lowest: compounds 1, 2 and 3 (each within the scatter of the next, the first and the last beyond it); then compound 4.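

In this assay, hydrogen in place of trifluoromethyl gives a 6.3-fold higher number from compound 2 to compound 4 (0.80 log units; beyond the scatter), so the group on this aromatic carbon carries real weight. Trifluoromethyl gives the lower number here, whereas a 3.5-fold higher number from compound 1 to compound 3 (0.55 log units; beyond the scatter) put it on the higher side against methyl, so hydrogen, trifluoromethyl and methyl need not form a simple order. Nothing available explains this result. The compounds shown leave open how a chlorine or a methoxy group would behave at this place. They also leave open how methyl would compare with hydrogen on a single background.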